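Shortening the alkyne chain from compound 3 to compound 4

The compounds below may be only part of what the source reports. "The series", "measured", "known", "first", "only" and "open" are said of these compounds alone.

For the measured compounds named here, compound 3 `CCCCC#Cc1cc(C)oc(=O)c1` gives 15500 nM in a functional assay on K562 cells (Homo sapiens) for inhibition (a higher number here means a weaker inhibitor, a lower number a stronger inhibitor), the second highest of the three numbers so far. Compound 2 `CCCCCCC#Cc1cc(C)oc(=O)c1` gives 20300 nM, within the scatter of compound 3, while compound 1 `Cc1cc(/C=C/COC2CCOCC2)cc(=O)o1` gives 4000 nM, a lower number that lies beyond the scatter. Compound 4 `C#Cc1cc(C)oc(=O)c1` has not been measured. It differs from compound 3 by hydrogen in place of butyl on a triple-bonded carbon. Going by the values given here, the one measured step that bears on this change is the earlier shortening at the same chain, a 1.3-fold lower number from compound 2 to compound 3 (0.12 log units; within the scatter), where the loss of the ethyl left the number unchanged within the scatter. Among the compounds with values here, the change to compound 4 removes the whole butyl and leaves a bare triple bond, a larger cut than the one measured, so the uncertainty is wider, but with only this one step to go on no shift beyond the scatter is expected in this assay, in either direction. Compound 4 is therefore expected to give 20000 nM, with a range of 7000 nM to 60000 nM, an expected step of a 1.3-fold higher number from compound 3 to compound 4 (0.11 log units; within the scatter).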

Compound 4, half-maximal inhibitory concentration: 2000 nM
Compound 4: the middle estimate sits 10-fold (1.00 log units) above what was measured; the whole stated range lies above it.
By their numbers in this assay, from the lowest: compounds 4 and 1 (each within the scatter of the next); then compounds 3 and 2 (each within the scatter of the next).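

In this assay, hydrogen in place of butyl on a triple-bonded carbon gives a 7.8-fold lower number from compound 3 to compound 4 (0.89 log units; beyond the scatter) and so moves the number beyond the scatter, whereas hydrogen in place of ethyl further along the chain gave only a 1.3-fold lower number from compound 2 to compound 3 (0.12 log units; within the scatter) and stayed within it. The number at this position therefore responds to the chain, but only the full removal of the butyl, leaving a bare triple bond, has shown this so far. Nothing in the data shown explains this step.

On these data alone, whether the number falls gradually or only when the chain is gone entirely stays open, and a methyl or propyl on the triple-bonded carbon would separate the two. Also open, as far as these compounds go, is how a hydroxymethyl or an amine on that carbon would compare with the hydrogen of compound 4.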